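Shifting a Methoxy Group in an Antiproliferative Series

The source may report more compounds than this note shows. Statements on the series, on what has been measured and on what is new or still open speak of the compounds shown alone.

Measured compounds:
compound 1, `Cc1ccc(NC(=O)Nc2cccc(CNc3ncnc4ccccc34)c2)cc1`: > 50000 nM
compound 2, `COc1ccccc1NC(=O)Nc1cccc(CNc2ncnc3ccccc23)c1`: 17500 nM

In a functional assay on HepG2 cells (Homo sapiens) for antiproliferative activity, read by MTT assay (on this read-out lower numbers stand for stronger inhibition and higher numbers for weaker inhibition), compound 1 gives > 50000 nM, and this figure is a limit of the assay rather than a measured number. In this assay, for the measured compounds named here, compound 2 gives 17500 nM, which is the only full number available; the other value is the limit of > 50000 nM in this assay, at which 1 of the 2 values shown sits. Going by the values given here, the single measured step is an at least 2.8-fold lower number from compound 1 to compound 2 (0.45 log units; beyond the scatter), brought about by a 2-methoxyphenyl in place of a 4-methylphenyl on an amide-type nitrogen.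

Compound 3, `COc1ccc(NC(=O)Nc2cccc(CNc3ncnc4ccccc34)c2)cc1`, differs from compound 2 by 4-methoxyphenyl in place of 2-methoxyphenyl on an amide-type nitrogen. The measured step does not isolate this change, since it exchanged the whole group at once, so it offers only a loose guide, and the small size of the measured set leaves the direction open. With that caution, compound 3 is expected to give 35000 nM, within a range from 12000 nM to 100000 nM, and there is a real chance that this assay again reports only a limit. This corresponds to an expected step of a 2.0-fold higher number from compound 2 to compound 3 (0.30 log units; within the scatter).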

Compound 3, half-maximal inhibitory concentration: > 50000 nM
Compound 3: no number, only a limit; the forecaster's own chance of this, stated with the estimate: 45%; at least 1.4-fold (0.15 log units) between middle value and limit.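

In this assay, exchanging 2-methoxyphenyl for 4-methoxyphenyl on the amide-type nitrogen gives an at least 2.8-fold higher number from compound 2 to compound 3 (0.45 log units; beyond the scatter). The earlier step changed the group as a whole, swapping 4-methylphenyl for 2-methoxyphenyl, so it could not show whether the methoxy group itself or its place on the ring mattered; this pair has the same atoms joined differently, and that rearrangement alone moves the result beyond the usual scatter. Compound 1 and compound 3 each stand at a limit of the assay rather than at a measured number, so the step between them, methoxy in place of methyl on an aromatic carbon, cannot be read: the limit of > 50000 nM in this assay, at which 2 of the 3 values shown sit.

Going by these compounds, it remains open whether the activity of compound 2 depends on the methoxy group specifically, or whether a hydroxyl, an ethoxy or an amine in its place on the same ring would give a similar number. With only one full value among these compounds, how far compound 1 and compound 3 actually lie from compound 2 also remains unknown.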